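A few compounds are considered here, and "the series" means these few. Any claim that something is new, unique, unknown or untested is made for them only; others in the source may bear on it.

Measured compounds:
- compound 1 `ClCc1ccc(Cn2cnc3c(Cl)ncnc32)cc1`: 4780 nM
- compound 2 `ClCc1ccccc1Cn1cnc2c(Cl)nc(Cl)nc21`: 440 nM

Two compounds have numbers in a functional assay on PC-3 cells (Homo sapiens) for cytotoxicity, read by sulforhodamine B assay, with a stated time of 48 h; a lower number here means a stronger inhibitor of growth, a higher number a weaker inhibitor of growth. Within the data shown here, compound 2 stands lowest of the two; compound 1 gives the only other number, and its value in this assay is 4780 nM, a gap beyond the usual scatter. Among the measured compounds shown here, no single-change step connects the two measured compounds: compound 1 and compound 2 differ both in the core substitution and in where the chloromethyl sits on the benzyl ring, so the two values show only that both changes together separate them.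

Compound 3 `ClCc1ccccc1Cn1cnc2c(Cl)ncnc21` is not yet measured. It keeps the benzyl group of compound 2 and differs from it in one place: hydrogen in place of chloro on an aromatic carbon. The core of compound 3 is that of compound 1.

For the measured compounds named here, no directly comparable step exists, so the expectation rests on the two numbers alone. Compound 3 is expected to move toward compound 1, whose value in this assay is 4780 nM, without reaching it, since the benzyl arrangement of compound 2 is retained. The step from compound 2 to compound 3 is estimated as a 3.4-fold higher number from compound 2 to compound 3 (0.53 log units; beyond the scatter), a loss beyond the scatter. Compound 3 is estimated at 1500 nM, with a range of 500 nM to 5000 nM.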

Compound 3, concentration for 50% growth inhibition: 3020 nM
Estimate against measurement, compound 3: 2.0-fold (0.30 log units) below; low and high end bracket the measured number.
By their numbers in this assay, from the lowest: compound 2; then compounds 3 and 1 (each within the scatter of the next).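

In this assay, among these compounds, the chloro on the aromatic carbon between two ring nitrogen atoms now has a single-change reading: hydrogen in its place gives a 6.9-fold higher number from compound 2 to compound 3 (0.84 log units; beyond the scatter) as the first step that isolates one place, and it lies beyond the scatter. Compound 3 gives 3020 nM and compound 1 gives 4780 nM within the scatter of each other, so with hydrogen at this place the two positions of the chloromethyl on the benzyl ring show no separable difference, and the mixed gap seen earlier between compound 1 and compound 2 can be matched by the loss of this chloro alone. Nothing measured here speaks to why this chloro matters in these cells.

The compounds shown leave open whether another group at this place, such as an amine, a methoxy group or a fluoro, would hold the value of compound 2 or fall back to that of compound 3. They also leave open whether the position of the chloromethyl matters once the chloro is present, and whether a plain methyl in place of the chloromethyl would keep any of this growth inhibition.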